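The source may report more compounds than this note shows. Statements on the series, on what has been measured and on what is new or still open speak of the compounds shown alone.

Working notes on the series. The shared core carries a propanamide in compound 1 `CCC(=O)Nc1c(C(O)(C(F)(F)F)C(F)(F)F)ccc2ccccc12`, a 2-methylbutanamide in compound 2 `CCC(C)C(=O)Nc1c(C(O)(C(F)(F)F)C(F)(F)F)ccc2ccccc12` and a cyclopropanecarboxamide in compound 3 `O=C(Nc1c(C(O)(C(F)(F)F)C(F)(F)F)ccc2ccccc12)C1CC1`. In an assay on LtK cells with ATP-sensitive inward rectifier potassium channel 11 (Homo sapiens) as the target (on this read-out lower numbers stand for an effect already at smaller amounts and higher numbers for an effect only at larger amounts of compound), compound 1 gives 15 nM, compound 2 gives 177000 nM and compound 3 gives 751 nM. Compound 3 therefore holds the second highest number of the three: a 50-fold higher number from compound 1 to compound 3 (1.70 log units; beyond the scatter), while a 240-fold lower number from compound 2 to compound 3 (2.37 log units; beyond the scatter). For the measured compounds named here, the one step among the chain amides, a 12000-fold higher number from compound 1 to compound 2 (4.07 log units; beyond the scatter), shows how strongly the group on the carbonyl carbon moves the read-out.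

The next compound, compound 4 `CC(C)OC(=O)Nc1c(C(O)(C(F)(F)F)C(F)(F)F)ccc2ccccc12`, replaces that group again: isopropoxy in place of cyclopropyl on a carbonyl carbon. Going by the values given here, no measured step exchanges a carbon group for an alkoxy group on the carbonyl carbon, so the three steps only set the scale of what a change at this position can do, not its direction. The two steps leaving compound 1 both lead to higher numbers, and the largest of them follows the more branched group, which argues against a lower number here. For compound 4 the step is therefore expected as a 4.0-fold higher number from compound 3 to compound 4 (0.60 log units; beyond the scatter), with wide uncertainty. The estimate for compound 4 in this assay is 3000 nM, with a range from 200 nM to 50000 nM.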

Compound 4, half-maximal effective concentration: 1160 nM
Beside the measured number, compound 4's estimate is 2.6-fold (0.41 log units) above it; low and high end bracket the measured number.
By their numbers in this assay, from the lowest: compound 1; then compounds 3 and 4 (each within the scatter of the next); then compound 2.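

In this assay, for the compounds shown here, the exchange of cyclopropyl for isopropoxy on a carbonyl carbon removes the three-membered ring and adds a hydrogen-bond acceptor, yet it gives a 1.5-fold higher number from compound 3 to compound 4 (0.19 log units; within the scatter), the first step at this position that does not stand out from the scatter. The isopropoxy group also shows that a branched group on the carbonyl carbon does not by itself give a number like that of compound 2, as a 150-fold lower number from compound 2 to compound 4 (2.18 log units; beyond the scatter) shows, although the position remains far from the low number of compound 1, with a 77-fold higher number from compound 1 to compound 4 (1.89 log units; beyond the scatter). Nothing at hand explains these steps.

From the compounds shown here alone, the contribution of the oxygen itself remains open, as a comparison of isopropoxy with isopropyl on the carbonyl carbon, or of ethyl with methoxy, would be needed to separate it from the size and shape of the group. Going by these compounds, it also remains open whether the low number of compound 1 is confined to ethyl or extends to a longer chain such as propyl, and whether a smaller group such as methyl would give a lower or higher number.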